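Guanidine substituent trimmed: benzylmethylaminopropyl to isopropyl

The compounds below may be only part of what the source reports. "The series", "measured", "known", "first", "only" and "open" are said of these compounds alone.

Measured so far:
compound 1 `CCCC/N=C(/N)NC(=O)c1cccc(F)c1CCc1cc(Br)ccc1OC` — 920 nM
compound 2 `COc1ccc(Br)cc1CCc1c(F)cccc1C(=O)/N=C(\N)NCCCCN(C)Cc1ccccc1` — 5.1 nM

In an assay for binding affinity to Melanocortin receptor 4 (Homo sapiens) (a lower number here means a stronger inhibitor, a higher number a weaker inhibitor), compound 2 gives 5.1 nM, the lowest of the two numbers recorded; compound 1 gives 920 nM, a far higher number, beyond the scatter. Within the data shown here, no step between measured compounds that differ in one place has been worked out.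

Compound 3 `COc1ccc(Br)cc1CCc1c(F)cccc1C(=O)/N=C(\N)NCC(C)C` has not been measured. It differs from compound 2 by isopropyl in place of 3-(benzyl(methyl)amino)propyl on a saturated chain carbon bound to an amine nitrogen. Compound 1, which also lacks the 3-(benzyl(methyl)amino)propyl group, gives 920 nM, and that is the only hint available for a guanidine carrying a small alkyl group on the shared core. A large step toward a weaker inhibitor is therefore expected, estimated as a 160-fold higher number from compound 2 to compound 3 (2.20 log units; beyond the scatter) in this assay. Compound 3 is expected to give about 800 nM, within roughly 200 nM to 3500 nM, close to where compound 1 stands.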

Compound 3, inhibition constant: 770 nM
Compound 3: middle estimate off by 1.0-fold (0.02 log units), on the high side; the measured number falls inside the stated range.
By their numbers in this assay, from the lowest: compound 2; then compounds 3 and 1 (each within the scatter of the next).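

a 150-fold higher number from compound 2 to compound 3 (2.18 log units; beyond the scatter) in this assay gives the first single-place measure of this change: on the shared core, isopropyl in place of 3-(benzyl(methyl)amino)propyl, on a saturated chain carbon bound to an amine nitrogen, is a large step. a 1.2-fold lower number from compound 1 to compound 3 (0.08 log units; within the scatter) lies within the scatter, so the two groups of equal heavy-atom count exchanged on a carbonyl carbon cannot be told apart in this assay. No supporting data bear on what lies behind the large step.

The amine nitrogen and the six-membered aromatic ring leave together in this change, so the compounds shown do not assign the step to either one. A chain ending in a dimethylamine and a phenylbutyl chain without nitrogen would separate the two contributions.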